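Thioamide to dithiolethione on a succinate-linked scaffold

This account rests on a few compounds, and the source may have more. Where it says the series, first, only, none or still open, it means among the compounds named here.

Compound 1 `COc1cc(CNC(=O)CCCCCCC(C)C)ccc1OC(=O)CCC(=O)Oc1ccc(C(N)=S)cc1` is tested in a functional assay on HeLa cells (Homo sapiens) for antiproliferative activity, read by MTT assay, with a stated time of 48 h (on this read-out higher numbers stand for weaker inhibition and lower numbers for stronger inhibition), where compound 1 gives only the assay limit of > 50000 nM. Compound 2 `COc1cc(CNC(=O)CCCC/C=C/C(C)C)ccc1OC(=O)CCC(=O)Oc1ccc(C(N)=S)cc1` likewise returns the limit > 50000 nM. Compound 3 `COc1cc(CNC(=O)CCCC/C=C/C(C)C)ccc1OCCCCCOc1ccc(-c2cc(=S)ss2)cc1` also stops at the limit > 50000 nM. Among the compounds with values here, the single change between measured compounds, a step that the two limits leave unreadable from compound 1 to compound 2, is therefore a step whose size the two limits do not reveal. Compound 4 `COc1cc(CNC(=O)CCCC/C=C/C(C)C)ccc1OC(=O)CCC(=O)Oc1ccc(-c2cc(=S)ss2)cc1` differs from compound 2 by a group of 6 heavy atoms (3 carbon, 3 sulfur; one five-membered aromatic ring with 2 hetero atoms) in place of a group of 3 heavy atoms (1 carbon, 1 nitrogen, 1 sulfur; no ring), on an aromatic carbon. Within the data shown here, no measured step bears directly on this change; the only evidence is the limit of > 50000 nM in this assay, at which 3 of the 3 values shown sit, so no step beyond the scatter can be expected in this assay in either direction. Compound 4 is accordingly estimated at 60000 nM, within 20000 nM to 200000 nM, an expected step that the limit leaves unreadable from compound 2 to compound 4.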

Compound 4, half-maximal inhibitory concentration: 4250 nM
For compound 4 the middle estimate is 14-fold (1.15 log units) above the measured one, outside the stated range (below it).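

Within the data shown here, the group with the five-membered aromatic ring, on this aromatic carbon para to a large group, produces an at least 11-fold lower number from compound 2 to compound 4 (1.07 log units; beyond the scatter) in this assay and so gives the first readable value here. Compound 3 carries the same ring group on a different linker and gives > 50000 nM as a limit of the assay, so the ring group alone does not bring a readable value. Readable values remain the exception: the limit of > 50000 nM in this assay, at which 3 of the 4 values shown sit.

Going by these compounds, whether a carboxylic acid or an amine on this aromatic carbon would also leave the limit stays open. So does whether the ring group would give a readable value alongside the saturated chain of compound 1.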